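Pyridin-2-yl in Place of Trifluoromethylphenyl: an Expected Value

A few compounds are considered here, and "the series" means these few. Any claim that something is new, unique, unknown or untested is made for them only; others in the source may bear on it.

Three compounds have been measured in an assay on HEK293 cells for inhibition of Voltage-dependent T-type calcium channel subunit alpha-1G (Homo sapiens), read by fluorescence, tested at 10 uM; a lower number here means less inhibition, a higher number more inhibition at the concentration tested (going by the name of the read-out):
Compound 1 `CCCc1nc(-c2ccccc2)c(CNCCN2CCN(c3ccccc3F)CC2)o1` gives 46.5%.
Compound 2 `CCCc1nc(-c2ccccc2)c(CNCCN2CCN(c3ccccc3OC)CC2)o1` gives 39.7%.
Compound 3 `CCCc1nc(-c2ccccc2)c(CNCCN2CCN(c3ccccc3C(F)(F)F)CC2)o1` gives 54.6%.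

Compound 3 is set apart from compound 2 by a number 14.9 percentage points higher from compound 2 to compound 3 (beyond the scatter), but not from compound 1, since a number 8.1 percentage points higher from compound 1 to compound 3 (within the scatter) lies within the scatter, as does a number 6.8 percentage points lower from compound 1 to compound 2 (within the scatter). Compound 4 `CCCc1nc(-c2ccccc2)c(CNCCN2CCN(c3ccccn3)CC2)o1` differs from compound 3 in one place: pyridin-2-yl in place of 2-(trifluoromethyl)phenyl on an amine nitrogen in a ring. For the measured compounds named here, none of the measured steps exchanges the whole ring; each swaps one small group on the phenyl ring, and only one reaches beyond the scatter. Exchanging the entire ring is a larger change than any of those, so a step beyond the scatter in this assay is plausible, and a modest fall is expected, a number 14.6 percentage points lower from compound 3 to compound 4 (beyond the scatter). Compound 4 is therefore estimated at 40%, between 20% and 60%.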

Compound 4, a percentage reported as inhibition, at one concentration (the size of the read-out at that concentration, not a potency): 48.1%
Compound 4: the middle estimate sits 8.1 percentage points below what was measured, within the range that was stated.
By their numbers in this assay, from the lowest: compounds 2, 1, 4 and 3 (each within the scatter of the next, the first and the last beyond it).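

Exchanging the whole ring on the amine nitrogen, rather than one small group on the phenyl ring, gives only small steps (a number 6.5 percentage points lower from compound 3 to compound 4 (within the scatter); a number 8.4 percentage points higher from compound 2 to compound 4 (within the scatter); a number 1.6 percentage points higher from compound 1 to compound 4 (within the scatter)). At this position, then, pyridin-2-yl cannot be told apart from any of the three substituted phenyl rings, although compound 2 and compound 3 can be told apart from each other. Nothing measured here explains this result. Still open, from the compounds shown here alone, is whether a ring without aromatic character, such as cyclohexyl, or an acetyl group on that nitrogen would give a similar number.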